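A Trifluoromethyl Swap Repeated on a Methylated Core

The source may report more compounds than this note shows. Statements on the series, on what has been measured and on what is new or still open speak of the compounds shown alone.

Compound 1 `Fc1ccc(-c2ccc(-c3ccc(-c4nc5ccccc5[nH]4)cc3)cc2)cc1` gives 100000 nM in a functional assay on ZR-75-1 cells (Homo sapiens) for inhibition, read by sulforhodamine B assay; a lower number here means a stronger inhibitor of growth, a higher number a weaker inhibitor of growth.
Compound 2 `FC(F)(F)c1ccc(-c2ccc(-c3ccc(-c4nc5ccccc5[nH]4)cc3)cc2)cc1` gives 48300 nM in this assay.
Compound 3 `Cc1ccc2[nH]c(-c3ccc(-c4ccc(-c5ccc(F)cc5)cc4)cc3)nc2c1` gives 35000 nM in this assay.

Two single changes branch out from compound 1. The first, (trifluoromethyl in place of fluoro on an aromatic carbon), gives a 2.1-fold lower number from compound 1 to compound 2 (0.32 log units; beyond the scatter). The second, (methyl in place of hydrogen on an aromatic carbon), gives a 2.9-fold lower number from compound 1 to compound 3 (0.46 log units; beyond the scatter). Compound 3 carries the lowest of the three numbers, but its value and that of compound 2 lie within the scatter of each other, so no order between those two can be drawn.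

Compound 4 `Cc1ccc2[nH]c(-c3ccc(-c4ccc(-c5ccc(C(F)(F)F)cc5)cc4)cc3)nc2c1` has not yet been measured in this assay. It differs from compound 3 by trifluoromethyl in place of fluoro on an aromatic carbon. Among the compounds with values here, this is the same change as the one from compound 1 to compound 2, made here on a core that differs from the core of compound 1 by methyl in place of hydrogen on an aromatic carbon. The place of the change reads the same in both cases.

Within the data shown here, with only one earlier instance of this change to rest on, the step from compound 3 to compound 4 is expected to resemble the earlier one: a 2.1-fold lower number from compound 3 to compound 4 (0.31 log units; beyond the scatter) is expected, set beside a 2.1-fold lower number from compound 1 to compound 2 (0.32 log units; beyond the scatter). On that basis compound 4 is estimated to give 17000 nM in this assay, with a likely range from 7000 nM to 40000 nM.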

Compound 4, concentration for 50% growth inhibition: 2410 nM
Estimate against measurement, compound 4: 7.1-fold (0.85 log units) above; the whole stated range lies above it.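

In this assay, the swap from fluoro to trifluoromethyl keeps its direction on the methylated core but not its size, giving a 15-fold lower number from compound 3 to compound 4 (1.16 log units; beyond the scatter), and the two instances clearly differ: the same change on two cores in this assay, a 2.1-fold lower number (0.32 log units; beyond the scatter) from compound 1 to compound 2 and a 15-fold lower number (1.16 log units; beyond the scatter) from compound 3 to compound 4, 7.0-fold (0.85 log units) apart, beyond the scatter of two such steps

Read from the other side of the same square, adding the methyl group to the core gives a 20-fold lower number from compound 2 to compound 4 (1.30 log units; beyond the scatter), which also departs from its earlier instance: the same change on two cores in this assay, a 2.9-fold lower number (0.46 log units; beyond the scatter) from compound 1 to compound 3 and a 20-fold lower number (1.30 log units; beyond the scatter) from compound 2 to compound 4, 7.0-fold (0.85 log units) apart, beyond the scatter of two such steps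

The two changes therefore do not act independently across these four compounds, since the size of each step depends on whether the other change is present, and compound 4 gains far more than either single step would suggest. This shows that the direction of the swap carried from one core to the other while its size did not, but it does not show why, and one pair of cores gives no general rule for the series.

Going by these compounds, it remains open whether a similar gain would appear if the trifluoromethyl group gave way to a nitrile or a carboxylic acid, or if the methyl group on the core gave way to a longer chain such as ethyl. On these data alone, it is also open whether an amine at that same place on the 4-substituted phenyl would follow the pattern of compound 4 or that of compound 2.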